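Swapping a phenol-bearing benzyl for a benzofuranylmethyl amine

A few compounds are considered here, and "the series" means these few. Any claim that something is new, unique, unknown or untested is made for them only; others in the source may bear on it.

Compound 1 `O[C@@H]1C[C@@H](C(c2ccc(F)cc2)c2ccc(F)cc2)OC[C@H]1NCc1ccc2c(c1)CCO2`: 17 nM
Compound 2 `COc1cc(CN[C@@H]2CO[C@H](C(c3ccccc3)c3ccccc3)C[C@H]2O)ccc1O`: 167 nM

In an assay on striatum for inhibition of sodium-dependent dopamine transporter (Rattus norvegicus) (a lower number here means a stronger inhibitor, a higher number a weaker inhibitor), compound 2 gives the highest of the two numbers, with compound 1 as its nearest neighbour at a much lower number. Compound 3 `O[C@@H]1C[C@@H](C(c2ccccc2)c2ccccc2)OC[C@H]1NCc1ccc2occc2c1` keeps the core of compound 2 and carries the change (1-benzofuran-5-yl in place of 4-hydroxy-3-methoxyphenyl on a saturated chain carbon bound to an amine nitrogen). Among the compounds with values here, no measured pair shows this exact change. Compound 1, which also carries a fused oxygen-containing bicyclic group on the amine, gives the lower number, so a step downward beyond the scatter is expected, a 4.2-fold lower number from compound 2 to compound 3 (0.62 log units; beyond the scatter). Compound 3 is estimated at 40 nM, within 12 nM to 130 nM.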

Compound 3, inhibition constant: 234 nM
Compound 3: the middle estimate sits 5.9-fold (0.77 log units) below what was measured; measured number above the stated range.
By their numbers in this assay, from the lowest: compound 1; then compounds 2 and 3 (each within the scatter of the next).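

In this assay, putting 1-benzofuran-5-yl in place of 4-hydroxy-3-methoxyphenyl gives a 1.4-fold higher number from compound 2 to compound 3 (0.15 log units; within the scatter). At this position, then, the hydrogen-bond donor can go and a fused five-membered aromatic ring can enter with no change beyond the scatter. Nothing at hand gives a reason for this result.

Going by these compounds, compound 1 differs from compound 3 in more than one place, so the source of its lower number stays open. Also open, on these data alone, is how a plain benzyl or an indol-5-ylmethyl group would compare here.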